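Propanoyl on the free hydroxy of compound 2

A few compounds are considered here, and "the series" means these few. Any claim that something is new, unique, unknown or untested is made for them only; others in the source may bear on it.

Of the compounds shown here, two have been read so far in a functional assay on Caco-2 cells (Homo sapiens) for cytotoxicity, read by MTT assay, with a stated time of 4 h; a higher number here means a weaker inhibitor, a lower number a stronger inhibitor. In that read-out, compound 1 `COC(=O)C1=CO[C@@H](O[C@@H]2O[C@H](COC(c3ccccc3)(c3ccccc3)c3ccccc3)[C@@H](OC(=O)O)[C@H](OC(C)=O)[C@H]2OC(C)=O)[C@@H]2[C@@H](C)[C@@H](OC(C)=O)C[C@H]12` gives 3.45 ug/mL. Compound 2 `COC(=O)C1=CO[C@@H](O[C@@H]2O[C@H](CO)[C@@H](OC(C)=O)[C@H](OC(C)=O)[C@H]2OC(C)=O)[C@@H]2[C@@H](C)[C@@H](OC(C)=O)C[C@H]12` is reported as "not active" (no number reported), so it has no place on the numerical scale and offers no number from which to count a step.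

Compound 3 `CCC(=O)OC[C@H]1O[C@@H](O[C@@H]2OC=C(C(=O)OC)[C@H]3C[C@H](OC(C)=O)[C@H](C)[C@@H]23)[C@H](OC(C)=O)[C@@H](OC(C)=O)[C@@H]1OC(C)=O` is the next to be read. The structural change is propanoyl in place of hydrogen on an oxygen on a saturated carbon. In words, propanoyl stands in place of hydrogen on an oxygen on a saturated carbon, turning hydroxymethyl into (propanoyloxy)methyl.

For the measured compounds named here, no measured pair shows this change, so the size of the step in this assay cannot be taken from data. The expected direction is towards stronger inhibition than compound 2, with a measurable value, though another report without a number remains quite possible. Going by the values given here, the only numerical reference is compound 1 at 3.45 ug/mL, and the expected value is set somewhat weaker than that. In this assay compound 3 is estimated at 8 ug/mL, with an expected range of 2 ug/mL to 40 ug/mL.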

Compound 3, half-maximal inhibitory concentration: 2.85 ug/mL
For compound 3 the middle estimate is 2.8-fold (0.45 log units) above the measured one; low and high end bracket the measured number.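

In this assay, for the compounds shown here, compound 3 gives 2.85 ug/mL and compound 2 carries only the report "not active", so no step between them can be read. The compounds shown leave open how large a change propanoyl in place of hydrogen brings on the scale of this read-out. No available measurement bears on the cause of this result.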